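The source may hold more compounds than are shown below. What is called first, only, known or untested is meant among the compounds shown, and "the series" means these compounds.

The compounds measured so far:
Compound 1, `CC(C)(C)c1ccc(C(=O)N2CCC3(CC2)C(=O)N(CC(=O)NCCC(=O)O)CN3c2ccccc2)cc1`: 11400 nM
Compound 2, `CC1(C)CC(OC(=O)CN2CN(c3ccccc3)C3(CCN(C(=O)c4ccc(C5CCCCC5)cc4)CC3)C2=O)CC(C)(C)N1`: 600 nM
Compound 3, `CC1(C)CC(OC(=O)CN2CN(c3ccccc3)C3(CCN(C(=O)c4ccc(C(C)(C)C)cc4)CC3)C2=O)CC(C)(C)N1`: 1300 nM

These three share a core and differ at two places. In an assay on HEK293 cells for displacement of a labelled ligand from NPC1-like intracellular cholesterol transporter 1 (Homo sapiens) (on this read-out higher numbers stand for weaker inhibition and lower numbers for stronger inhibition), compound 3 gives the second highest of the three numbers; its steps to the other two are a 2.2-fold higher number from compound 2 to compound 3 (0.34 log units; beyond the scatter) and an 8.8-fold lower number from compound 1 to compound 3 (0.94 log units; beyond the scatter), both beyond the scatter.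

Compound 4, `CC(C)(C)c1ccc(C(=O)N2CCC3(CC2)C(=O)N(CC(=O)NCCCNS(C)(=O)=O)CN3c2ccccc2)cc1`, is not yet measured. It departs from compound 3 at the carbonyl carbon: (3-(methanesulfonamido)propyl)amino in place of (2,2,6,6-tetramethylpiperidin-4-yl)oxy on a carbonyl carbon. Among the compounds with values here, the only measured step at this position is an 8.8-fold lower number from compound 1 to compound 3 (0.94 log units; beyond the scatter), in which a (2-carboxyethyl)amino group gave a clearly higher number than a (2,2,6,6-tetramethylpiperidin-4-yl)oxy group. Compound 4 again carries an open chain joined through a nitrogen at this carbonyl carbon, as compound 1 does, though the chain ends differently, so a step back towards the number of compound 1 seems more likely than a step down. The step from compound 2 to compound 3 concerns the other end of the molecule and says nothing about this position. Compound 4 is therefore expected to show a 3.1-fold higher number from compound 3 to compound 4 (0.49 log units; beyond the scatter) in this assay, a modest rise. The estimate for compound 4 is 4000 nM, with a range from 1300 nM to 12000 nM.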

Compound 4, half-maximal inhibitory concentration: 10400 nM
Compound 4: the middle estimate sits 2.6-fold (0.41 log units) below what was measured; low and high end bracket the measured number.
By their numbers in this assay, from the lowest: compound 2; then compound 3; then compounds 4 and 1 (each within the scatter of the next).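

In this assay, putting (3-(methanesulfonamido)propyl)amino in place of (2,2,6,6-tetramethylpiperidin-4-yl)oxy on the carbonyl carbon gives an 8.0-fold higher number from compound 3 to compound 4 (0.90 log units; beyond the scatter), which is close in size to the earlier 8.8-fold lower number from compound 1 to compound 3 (0.94 log units; beyond the scatter), read in the opposite direction, so a second open chain joined through nitrogen now sits on the weaker side of compound 3. The end of that chain makes no readable difference, since the swap of carboxy for (methanesulfonamido)methyl gives a 1.1-fold lower number from compound 1 to compound 4 (0.04 log units; within the scatter), and so, among these compounds, the two chain ends cannot be told apart. Nothing available here explains why the chains give higher numbers than the (2,2,6,6-tetramethylpiperidin-4-yl)oxy group.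

The step from compound 3 to compound 4 changes both the oxygen link to a nitrogen link and the ring to an open chain, so a (2,2,6,6-tetramethylpiperidin-4-yl)amino group, which keeps the ring on a nitrogen link, or a simple alkoxy chain, which keeps the oxygen link without the ring, would be needed to separate the two. From the compounds shown here alone, whether a cyclohexyl group in place of tert-butyl on the aromatic carbon would also lower the number for a compound carrying such a chain remains open as well.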